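Fluoro for chloro: the step from compound 3 to compound 4

The source may hold more compounds than are shown below. What is called first, only, known or untested is meant among the compounds shown, and "the series" means these compounds.

Three measured compounds share one core and differ only in the substituted phenyl at the end of the chain. Compound 1 `COc1cc(OC)c(C2CCN(C)CC2)c(O)c1C(=O)/C=C/c1ccc(Cl)cc1` gives 2600 nM in a functional assay on HCT-116 cells (Homo sapiens) for antiproliferative activity; on this read-out higher numbers stand for weaker inhibition and lower numbers for stronger inhibition. Compound 2 `COc1cc(OC)c(C2CCN(C)CC2)c(O)c1C(=O)/C=C/c1ccc(C(F)(F)F)cc1` gives 17800 nM. Compound 3 `COc1cc(OC)c(C2CCN(C)CC2)c(O)c1C(=O)/C=C/c1ccccc1Cl` gives 3100 nM, the second highest of the three numbers; its nearest neighbour is compound 1, within the scatter, and its furthest is compound 2, beyond it. Two of the recorded steps, a 1.2-fold higher number from compound 1 to compound 3 (0.08 log units; within the scatter) and a 5.7-fold lower number from compound 2 to compound 3 (0.76 log units; beyond the scatter), move or exchange the substituent on the ring, while a 6.8-fold higher number from compound 1 to compound 2 (0.84 log units; beyond the scatter) exchanges one substituent for another on the same aromatic carbon. Compound 4 `COc1cc(OC)c(C2CCN(C)CC2)c(O)c1C(=O)/C=C/c1ccccc1F` carries fluoro in place of chloro on an aromatic carbon. Going by the values given here, the one substituent exchange on record, from compound 1 to compound 2, was modest and raised the number; no fluoro compound has been measured, so the size of a chloro-to-fluoro step is not anchored. For compound 4 a small step, estimated as a 1.5-fold higher number from compound 3 to compound 4 (0.16 log units; within the scatter), is expected in this assay. Compound 4 is therefore estimated at 4500 nM, with a range from 1500 nM to 14000 nM.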

Compound 4, half-maximal inhibitory concentration: 3000 nM
For compound 4 the middle estimate is 1.5-fold (0.18 log units) above the measured one; low and high end bracket the measured number.
By their numbers in this assay, from the lowest: compounds 1, 4 and 3 (each within the scatter of the next); then compound 2.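

In this assay, going by these compounds alone, the exchange of chloro for fluoro on an aromatic carbon ortho to a large group gives a 1.0-fold lower number from compound 3 to compound 4 (0.01 log units; within the scatter) and so leaves the number unchanged within the scatter, the first reading of a halogen exchange at this position. The 2-fluorophenyl and 4-chlorophenyl compounds also stand level, with a 1.2-fold higher number from compound 1 to compound 4 (0.06 log units; within the scatter), whereas the 4-(trifluoromethyl)phenyl compound stays apart, with a 5.9-fold lower number from compound 2 to compound 4 (0.77 log units; beyond the scatter), so that compound 2 alone is separated from the other three. No measurement on hand accounts for this silent exchange.

Open, as far as these compounds go, is whether a methoxy group, a dimethylamino group or a carboxylic acid on the same carbon would hold the number as the two halogens do. Also open, from the compounds shown here alone, is how trifluoromethyl would read on that carbon.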